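Fluoro for methyl on the anilino ring of a thiophene acid

A few compounds are considered here, and "the series" means these few. Any claim that something is new, unique, unknown or untested is made for them only; others in the source may bear on it.

Measured so far:
compound 1 `Cc1ccc(C(=O)c2sc(Nc3ccccc3)c(C(=O)O)c2C)cc1`: 0.85%
compound 2 `Cc1ccc(Nc2sc(C(=O)c3ccc(C)cc3)c(C)c2C(=O)O)cc1`: "not active" (no number reported)

In a functional assay, with a stated time of 150 min, tested at 10 ug/mL (a lower number here means a weaker effect, a higher number a stronger effect of the compound at the concentration tested), compound 1 gives 0.85%. In this assay compound 2 is reported as "not active" (no number reported), so no single number marks where it stands. Compound 3 `Cc1ccc(C(=O)c2sc(Nc3ccc(F)cc3)c(C(=O)O)c2C)cc1` differs from compound 2 by fluoro in place of methyl on an aromatic carbon. Both measured compounds sit at the weak end of the read-out, and nothing shown points to a step beyond the usual scatter in either direction. Compound 3 is therefore expected to give 1%, within 0% to 10%.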

Compound 3, a percentage reported as activity, at one concentration (the size of the read-out at that concentration, not a potency): "not active" (no number reported)
No number was reported for compound 3; there is nothing to compare the estimate with.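

Compound 2 and compound 3 are both reported without a number, so no step can be read between them. No measured evidence bears on this result. Going by these compounds, whether fluoro in place of methyl changes the effect at all stays open.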